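Pyrimidin-5-yl in place of pyridin-3-yl in compound 3

This account rests on a few compounds, and the source may have more. Where it says the series, first, only, none or still open, it means among the compounds named here.

Measured in a physicochemical assay for solubility, using the shake flask method, in phosphate buffer, with a stated time of 24 h, at pH 7.4; a lower number here means a less soluble compound, a higher number a more soluble compound:
Compound 1 `CC(Sc1nc2c(cnn2C)c(=O)n1-c1ccccc1)c1cccnc1`: 209000 nM
Compound 2 `CC(Sc1nc2nn(C3COC3)cc2c(=O)n1-c1ccccc1)c1cccnc1`: 189000 nM

These two values sit within the usual scatter of repeated measurements, so compound 1 and compound 2 cannot be told apart in this assay. Compound 1, at 209000 nM, is the starting point here.

The next compound to be tested is compound 3 `CC(Sc1nc2c(cnn2C)c(=O)n1-c1ccccc1)c1cncnc1`. It keeps the shared core of compound 1 and changes one group: pyrimidin-5-yl in place of pyridin-3-yl on a saturated chain carbon bound to a saturated chain carbon and a sulfur. The new group is pyrimidin-5-yl in place of pyridin-3-yl, on a saturated chain carbon bound to a saturated chain carbon and a sulfur.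

Among the compounds with values here, no measured pair shows this change, so the expectation rests on compound 1 alone, at 209000 nM. The expected step is a 1.1-fold higher number from compound 1 to compound 3 (0.04 log units; within the scatter), which would not rise beyond the scatter. For compound 3 the estimated value is 230000 nM, with an expected range from 110000 nM to 450000 nM.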

Compound 3, solubility: 264000 nM
Estimate against measurement, compound 3: 1.1-fold (0.06 log units) below; low and high end bracket the measured number.
By their numbers in this assay, from the lowest: compounds 2, 1 and 3 (each within the scatter of the next).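

In this assay, within the data shown here, the first measured change at this position, pyrimidin-5-yl in place of pyridin-3-yl on a saturated chain carbon bound to a saturated chain carbon and a sulfur, gives a 1.3-fold higher number from compound 1 to compound 3 (0.10 log units; within the scatter), so compound 1 and compound 3 cannot be told apart. In this single pair, a six-membered aromatic ring with 2 hetero atoms and one with 1 hetero atom therefore give solubility readings that are indistinguishable, although one pair cannot establish a general rule. No measurement here offers an explanation for this result.

Going by these compounds, it remains open whether a group of a different kind in this place, such as an amine or a carboxylic acid, would move the reading beyond the scatter. A single swap also cannot show whether the same ring change would give a similar result on a different core.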